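The source may hold more compounds than are shown below. What is called first, only, known or untested is meant among the compounds shown, and "the series" means these compounds.

Measured so far, in a functional assay on the whole organism (blood) with Rattus norvegicus as the target, with stated times of 24 h and 1 h, at a dose of 5 mg/kg by the intraperitoneal route; a lower number here means a weaker effect, a higher number a stronger effect of the compound at the dose given:
Compound 1 `COc1ccc(Cl)cc1C(=O)NCCC1CCN(S(=O)(=O)NC(=O)NC[C@@H]2C[C@@H]3C=C[C@@H]2C3)CC1` gives 37%
Compound 2 `O=C(NC1CCCCC1)NS(=O)(=O)N1CCC(CCNC(=O)C(F)(F)F)CC1` gives 13%

Compound 2 stands lowest of the two numbers in this assay; compound 1 lies higher by a gap beyond the usual scatter. Compound 3 `O=C(NC[C@@H]1C[C@@H]2C=C[C@@H]1C2)NS(=O)(=O)N1CCC(CCNC(=O)C(F)(F)F)CC1` has not yet been measured. It differs from compound 2 in one place: a group of 8 heavy atoms (8 carbon; 2 five-membered non-aromatic rings of carbon only) in place of a group of 6 heavy atoms (6 carbon; one six-membered non-aromatic ring of carbon only), on an amide-type nitrogen. For the measured compounds named here, no measured pair shows the effect of this change alone, so the size of its step is open. A moderate rise is expected, a number 12 percentage points higher from compound 2 to compound 3 (beyond the scatter), because compound 1 gives 37% while carrying the same entering group. Compound 3 is therefore estimated at 25%, within 8% to 45%.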

Compound 3, a percentage reported as activity, at one dose (the size of the read-out at that dose, not a potency): 22%
The estimate for compound 3 lay 3 percentage points above the measured number, within the range that was stated.
By their numbers in this assay, from the lowest: compounds 2 and 3 (each within the scatter of the next); then compound 1.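

In this assay the step is a number 9 percentage points higher from compound 2 to compound 3 (within the scatter) when the group of 8 heavy atoms with 2 five-membered rings replaces cyclohexyl on the amide-type nitrogen, so this swap shows no clear effect. The step of a number 15 percentage points lower from compound 1 to compound 3 (beyond the scatter) comes with trifluoromethyl in place of 5-chloro-2-methoxyphenyl on a carbonyl carbon, so that place shows the clearer change. No measurement at hand explains either step. Still open, on these data alone, is how a phenyl ring or a methyl group on the amide-type nitrogen would read. Also open, as far as these compounds go, is whether 5-chloro-2-methoxyphenyl gives a similar step with cyclohexyl present.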